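Dichlorophenyl Variant Read by Paw Edema Inhibition

This account rests on a few compounds, and the source may have more. Where it says the series, first, only, none or still open, it means among the compounds named here.

Compound 2 `COc1ccc(/C=C2/N=C(c3ccccc3)N(c3ccc4oc(-c5ccccc5)cc(=O)c4c3)C2=O)cc1` gives 45.1% in a functional assay on the whole organism (strain Wistar) for inhibition, with Rattus norvegicus as the target, read by paw edema, with a stated time of 3 h, at a dose of 100 mg/kg by the oral route (a higher number here means more inhibition at the dose given (going by the name of the read-out), a lower number less inhibition), and stands highest of the two numbers measured, by a margin within the scatter; compound 1 `O=C1/C(=C\c2ccccc2)N=C(c2ccccc2)N1c1ccc2oc(-c3ccccc3)cc(=O)c2c1` gives 38.3%. For the measured compounds named here, the one measured step, a number 6.8 percentage points higher from compound 1 to compound 2 (within the scatter), is within the scatter. Compound 3 `O=C1/C(=C\c2ccc(Cl)c(Cl)c2)N=C(c2ccccc2)N1c1ccc2oc(-c3ccccc3)cc(=O)c2c1` carries 3,4-dichlorophenyl in place of 4-methoxyphenyl on a double-bonded chain carbon bound to a double-bonded ring carbon. Going by the values given here, no measured step places a dichlorophenyl here, so the only guide is that exchanging the group in this position between compound 1 and compound 2 moved the number little. Compound 3 is therefore expected to show a number 3.1 percentage points lower from compound 2 to compound 3 (within the scatter), nothing beyond the scatter, and is estimated at 42%, between 30% and 55%.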

Compound 3, a percentage reported as inhibition, in the whole organism at one dose (the size of the read-out at that dose, not a potency): 36.5%
The estimate for compound 3 lay 5.5 percentage points above the measured number; the measured number falls inside the stated range.
By their numbers in this assay, from the lowest: compounds 3, 1 and 2 (each within the scatter of the next).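

In this assay, the 3,4-dichlorophenyl group in place of 4-methoxyphenyl gives a number 8.6 percentage points lower from compound 2 to compound 3 (within the scatter), and in place of phenyl it gives a number 1.8 percentage points lower from compound 1 to compound 3 (within the scatter). On a double-bonded chain carbon bound to a double-bonded ring carbon, the three aromatic groups now shown therefore cannot be told apart, whether the ring carries methoxy, chlorine or neither. No supporting evidence bears on this result. The compounds shown leave open whether an amine or a carboxylic acid on this ring would give a number beyond the scatter. They also leave open how the number would respond to a longer chain here.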